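Swapping hydroxyphenyl groups in a growth-inhibition series

The source may hold more compounds than are shown below. What is called first, only, known or untested is meant among the compounds shown, and "the series" means these compounds.

- compound 1 `CCCCCCn1cnc2c(Nc3ccc(O)cc3)nc(N[C@H]3CC[C@H](N)CC3)nc21` gives 7700 nM
- compound 2 `CC(C)CCn1cnc2c(Nc3cccc(O)c3)nc(N[C@H]3CC[C@H](N)CC3)nc21` gives 14700 nM
- compound 3 `CC(C)CCn1cnc2c(Nc3ccc(O)cc3)nc(N[C@H]3CC[C@H](N)CC3)nc21` is not yet measured

Both values come from a functional assay on BT-474 cells (Homo sapiens) for inhibition, read by fluorescence, with a stated time of 72 h (a lower number here means a stronger inhibitor of growth, a higher number a weaker inhibitor of growth), and lie within the scatter of each other, so compound 2 stands level with compound 1 and the two cannot be ranked. Compound 3 differs from compound 2 in one place, with 4-hydroxyphenyl in place of 3-hydroxyphenyl on a nitrogen on an aromatic ring. Going by the values given here, no measured pair shows this change alone, so its size cannot be read from the data. With compound 1 at 7700 nM and compound 2 at 14700 nM in this assay there is no ground for expecting a large step. The estimated step (a 1.5-fold lower number from compound 2 to compound 3 (0.17 log units; within the scatter)) is expected to stay within the scatter, leaning slightly towards a lower number. For compound 3 the expected value is 10000 nM (estimated range 4500 nM to 22000 nM).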

Compound 3, concentration for 50% growth inhibition: 7700 nM
Compound 3: middle estimate off by 1.3-fold (0.11 log units), on the high side; measured number inside the range.
By their numbers in this assay, from the lowest: compounds 1, 3 and 2 (each within the scatter of the next).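

In this assay, 4-hydroxyphenyl in place of 3-hydroxyphenyl on a nitrogen on an aromatic ring gives a 1.9-fold lower number from compound 2 to compound 3 (0.28 log units; within the scatter), so this change, now read alone in a matched pair, does not separate the two compounds. The chain can now also be read alone: isopropyl in place of butyl on a saturated chain carbon, two bonds along the chain from an aromatic nitrogen, gives no change at the digits printed from compound 1 to compound 3 (within the scatter), so neither change shows an effect that can be told from the scatter. Nothing measured here offers an explanation for either result.

Still open, going by these compounds, is whether methoxyphenyl or unsubstituted phenyl on that nitrogen would give a step beyond the scatter. The same question stands for a cyclohexylmethyl group in place of the chain on the aromatic nitrogen.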